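Trading a methoxyphenyl group for a short hydroxyethyl chain

The compounds below may be only part of what the source reports. "The series", "measured", "known", "first", "only" and "open" are said of these compounds alone.

Compound 1 `CC1(C)OCC(Cn2cc(C(O)c3ccc(C(F)(F)F)cc3)nn2)O1`: > 100000 nM in a functional assay on B16 cells (Mus musculus) for cytotoxicity, read by MTT assay, with a stated time of 48 h; on this read-out higher numbers stand for weaker inhibition and lower numbers for stronger inhibition
Compound 2 `COc1ccc(C(O)c2cn(Cc3cccc(OC)c3)nn2)cc1`: > 100000 nM in this assay
Compound 3 `COc1cccc(Cn2cc(C(O)c3ccc(C)cc3)nn2)c1`: > 100000 nM in this assay

Each of these three values is a limit of this assay and not a measured number: the limit of > 100000 nM in this assay, at which 3 of the 3 values shown sit. Compound 2 therefore stands at that limit, with no number of its own that could be compared. Among the measured compounds shown here, the one step computed among the measured compounds, a step that the two limits leave unreadable from compound 2 to compound 3, cannot be read in size or direction, since both ends of it are limits.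

The unmeasured compound 4 `COc1ccc(C(O)c2cn(CCCO)nn2)cc1` differs from compound 2 by 2-hydroxyethyl in place of 3-methoxyphenyl on a saturated chain carbon bound to an aromatic nitrogen. No measured step touches this kind of change, and the single step available is unreadable, so nothing among these compounds points to a move in either direction. Compound 4 is expected to give about 100000 nM in this assay, between 30000 nM and 500000 nM, most probably again reported as a limit. The expected step is accordingly a number no higher from compound 2 to compound 4 (the limit leaves the size open), that is, essentially none.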

Compound 4, half-maximal inhibitory concentration: > 100000 nM
Compound 4: a limit, no number (the forecaster's own chance of this, stated with the estimate: 85%); the middle value lies on the limit itself.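

Compound 4 is again a limit and not a number, so the step from compound 2 to compound 4 cannot be read in size or direction, because both ends sit at the same limit: the limit of > 100000 nM in this assay, at which 4 of the 4 values shown sit.

The compounds shown leave open which structure, if any, would give in this assay a measured number instead of a limit.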